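Fluoro to trifluoromethyl on the shared core of compound 2

The compounds below may be only part of what the source reports. "The series", "measured", "known", "first", "only" and "open" are said of these compounds alone.

The measurements come from a functional assay on CHO cells for antagonist activity at sphingosine 1-phosphate receptor 2 (Homo sapiens), read by calcium flux; on this read-out lower numbers stand for stronger inhibition and higher numbers for weaker inhibition. Compound 1 `COc1cc(OC)c(NC(=O)Cc2cn(C)c3ccccc23)cc1Cl` gives only a limit there, > 8130 nM, rather than a number. Compound 2 `O=C(O)Cn1nc(Cc2nc3cc(F)c(OCC4CC4)cc3[nH]2)c2ccccc2c1=O` gives 18 nM in this assay. Compound 3 `CC(C(=O)O)c1nn(Cc2cn3cc(OCC4CC4)c(Cl)cc3n2)c2ccccc2c1=O` gives 6 nM in this assay. Among the two numbers that are not limits, compound 2 has the higher one. The gap between compound 2 and compound 3 is wider than the usual scatter of repeated measurements. Compound 4 `O=C(O)Cn1nc(Cc2nc3cc(C(F)(F)F)c(OCC4CC4)cc3[nH]2)c2ccccc2c1=O` is a new compound that keeps the whole frame of compound 2 and differs from it in a single place: trifluoromethyl in place of fluoro on an aromatic carbon. Among the measured compounds shown here, no pair of measured compounds differing in just one place is available here, so there is no measured step to lean on. Compound 4 is expected to land near 15 nM, with a plausible range from 5 nM to 50 nM. The step that this estimate implies, a 1.2-fold lower number from compound 2 to compound 4 (0.08 log units; within the scatter), is expected to stay within the usual scatter, in either direction.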

Compound 4, half-maximal inhibitory concentration: 6.6 nM
Compound 4: the middle estimate sits 2.3-fold (0.36 log units) above what was measured, within the range that was stated.
By their numbers in this assay, from the lowest: compounds 3 and 4 (each within the scatter of the next); then compound 2. At a limit, above all of these: compound 1.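

Among the compounds shown here, this is the first measured step at this position on the shared core. In this assay, trifluoromethyl in place of fluoro gives a 2.7-fold lower number from compound 2 to compound 4 (0.44 log units; beyond the scatter), so the step is modest but real. The aromatic carbon ortho to the cyclopropylmethoxy group can therefore carry trifluoromethyl, with 4 heavy atoms against 1 for fluoro, and the number still falls rather than rises.

With only fluoro and trifluoromethyl shown on this carbon, two groups cannot reveal how the number would respond to something quite different there, such as a nitrile or an amine, so the wider trend at this position remains open. The measurements shown also offer nothing that bears on why the number moved in this step.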